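Aryl swap at the pyrazole core: phenyl to pyrazinyl

The source may report more compounds than this note shows. Statements on the series, on what has been measured and on what is new or still open speak of the compounds shown alone.

Two compounds of the series have numbers in a functional assay on BJAB cells (Homo sapiens) for antiproliferative activity, with a stated time of 4 days; on this read-out lower numbers stand for an effect already at smaller amounts and higher numbers for an effect only at larger amounts of compound. Compound 1 `COc1cncc(-c2c(C)nn(-c3nc(-c4ccc(Cl)c(Cl)c4)c(SC(C)C)s3)c2C(=O)O)c1` gives 21000 nM in this assay. Compound 2 `COc1ccccc1-c1c(C)nn(-c2nc(-c3ccc(Cl)c(Cl)c3)c(SC(C)C)s2)c1C(=O)O` gives 14700 nM in this assay, the lowest of the two numbers, but the step between them is a 1.4-fold lower number from compound 1 to compound 2 (0.15 log units; within the scatter), so nothing separates them. Compound 3 `Cc1nn(-c2nc(-c3ccc(Cl)c(Cl)c3)c(SC(C)C)s2)c(C(=O)O)c1-c1cnccn1` is not yet measured. It differs from compound 2 in one place: pyrazin-2-yl in place of 2-methoxyphenyl on an aromatic carbon. Among the compounds with values here, the only measured step that bears on this change is the aryl exchange a 1.4-fold lower number from compound 1 to compound 2 (0.15 log units; within the scatter), where a six-membered ring with a ring nitrogen was replaced by a carbon-only ring without any shift beyond the scatter. The step to compound 3 again exchanges this aryl group, so no shift beyond the scatter is expected in this assay, and the estimated step is a 1.2-fold higher number from compound 2 to compound 3 (0.06 log units; within the scatter). For compound 3 the expected number in this assay is 17000 nM, with a range from 6000 nM to 50000 nM.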

Compound 3, half-maximal effective concentration: 14000 nM
Beside the measured number, compound 3's estimate is 1.2-fold (0.08 log units) above it; the range from low to high includes it.
By their numbers in this assay, from the lowest: compounds 3, 2 and 1 (each within the scatter of the next).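

In this assay the exchange of 2-methoxyphenyl for pyrazin-2-yl on this aromatic carbon gives a 1.1-fold lower number from compound 2 to compound 3 (0.02 log units; within the scatter) and stays within the scatter, while the exchange of 5-methoxypyridin-3-yl for pyrazin-2-yl gives a 1.5-fold lower number from compound 1 to compound 3 (0.18 log units; within the scatter) and also stays within it. The earlier pair both carried a methoxy group on the aryl ring; this result adds a ring with 2 hetero atoms, no methoxy group and 6 heavy atoms in place of 8, still without a shift beyond the scatter. No data on any property of these groups accompany the result.

As far as these compounds go, whether a non-aromatic group at this place, such as a morpholine or a short alkyl chain, would shift the number stays open. So does the effect of an amine on the aryl ring.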